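The source may hold more compounds than are shown below. What is called first, only, known or untested is meant among the compounds shown, and "the series" means these compounds.

Measured compounds, in an ADME assay on L02 cells (Homo sapiens) for cytotoxicity, read by MTT assay, with a stated time of 48 h; a lower number here means a stronger inhibitor, a higher number a weaker inhibitor:
Compound 1 `O=c1ccoc2cc(OCc3cn(Cc4cccc(Br)c4)nn3)ccc12`: > 300000 nM (a limit of the assay)
Compound 2 `O=c1ccoc2cc(OCc3cn(Cc4cccc([N+](=O)[O-])c4)nn3)ccc12`: > 300000 nM (a limit of the assay)

In this assay, compound 2 stands only at a limit, > 300000 nM, and no number is available for it. Among the measured compounds shown here, the same holds for the one other measured compound, and the record so far is the limit of > 300000 nM in this assay, at which 2 of the 2 values shown sit.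

The compound still to be measured is compound 3 `O=c1ccoc2cc(OCc3cn(Cc4ccccc4Br)nn3)ccc12`. The change is 2-bromophenyl in place of 3-nitrophenyl on a saturated chain carbon bound to an aromatic nitrogen.

For the measured compounds named here, only one measured step bears on this change, a step that the two limits leave unreadable from compound 1 to compound 2, with nitro in place of bromo on an aromatic carbon. That step gives no size to carry forward, and it offers no direction either. With both measured values at a limit, no step beyond the usual scatter is expected in this assay, though this expectation rests on very little. The estimated step is a number no higher from compound 2 to compound 3 (the limit leaves the size open). For compound 3 the expected value is 300000 nM, with an estimated range from 120000 nM to 600000 nM, and a report of only a limit is the likeliest outcome.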

Compound 3, half-maximal inhibitory concentration: > 300000 nM
Compound 3: only a limit was reported; the forecaster's own chance of this, stated with the estimate: 80%; the middle value sits exactly at the limit.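

In this assay compound 3, like compound 1 and compound 2, is reported only as a limit, so no step among these three compounds can be read. All of them stand at the same place: the limit of > 300000 nM in this assay, at which 3 of the 3 values shown sit. The compounds shown leave open how far each lies from that limit and whether any change to the group on the saturated chain carbon would give a measurable value.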